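Mouse microsomal half-life: aryl swap on the shared core

The source may hold more compounds than are shown below. What is called first, only, known or untested is meant among the compounds shown, and "the series" means these compounds.

Of the compounds shown here, three on the shared core have been measured in an ADME assay on microsomes from liver (Mus musculus) for metabolic stability; on this read-out lower numbers stand for a shorter-lived compound and higher numbers for a longer-lived compound. Compound 1 `NS(=O)(=O)CC(=O)NCCSc1nonc1/C(=N/O)Nc1cccc(Cl)c1` gives 1.26 h, the highest of the three numbers. Compound 2 `C[C@H](CSc1nonc1/C(=N/O)Nc1ccc(F)c(Br)c1)NC(=O)CS(N)(=O)=O` gives 0.537 h, which is beyond the scatter below compound 1. Compound 3 `CS(=O)(=O)NCCSc1nonc1/C(=N/O)Nc1ccc(F)c(Br)c1` gives 0.29 h, the furthest from compound 1 and again beyond the scatter. No pair among these three differs in one place only, so nothing of the group on the amine nitrogen can be separated from the other changes between them.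

Compound 4 `NS(=O)(=O)CC(=O)NCCSc1nonc1/C(=N/O)Nc1ccc(F)c(C(F)F)c1` differs from compound 1 in one place: 3-(difluoromethyl)-4-fluorophenyl in place of 3-chlorophenyl on an amine nitrogen. The two measured compounds that carry a fluorine-bearing ring, compound 2 and compound 3, both sit lower than compound 1, but they also differ from it elsewhere, so that can serve only as a loose hint of direction. The expected step from compound 1 to compound 4 in this assay is a modest decrease, a 1.6-fold lower number from compound 1 to compound 4 (0.20 log units; within the scatter), near the edge of the scatter. For compound 4 the estimated half-life is 0.8 h, with a range from 0.35 h to 1.8 h.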

Compound 4, half-life: 1.07 h
The estimate for compound 4 lay 1.3-fold (0.13 log units) below the measured number, within the range that was stated.
By their numbers in this assay, from the lowest: compounds 3, 2, 4 and 1 (each within the scatter of the next, the first and the last beyond it).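

For the compounds shown here, the first single-place comparison is a 1.2-fold lower number from compound 1 to compound 4 (0.07 log units; within the scatter) in this assay, with 3-(difluoromethyl)-4-fluorophenyl in place of 3-chlorophenyl on an amine nitrogen. With the rest of compound 1 held fixed, the half-life does not separate these two rings, even though the entering ring has 10 heavy atoms against 7 for the one that leaves. No available data bear on why the two rings read alike.

Going by these compounds, the swap replaces chlorine with both difluoromethyl and fluorine, so the contribution of each group remains open. Also open, on these data alone, are how a trifluoromethyl or methoxy group on the ring would read with the rest of compound 1 unchanged, and whether this ring swap would read the same on a different chain.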